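A nitro group added to compound 2

This account rests on a few compounds, and the source may have more. Where it says the series, first, only, none or still open, it means among the compounds named here.

Within the data shown here, only two compounds have been measured so far. Compound 1 `CCOC(=O)c1cccnc1S(=O)(=O)NC(=O)Nc1ccc(Cl)cc1` gives > 100000 nM in a functional assay on MEL-AC cells for cytotoxicity against MEL-AC cell line (Homo sapiens) (on this read-out higher numbers stand for weaker inhibition and lower numbers for stronger inhibition), and this entry is a limit of the assay, not a number. Among the measured compounds shown here, compound 2 `CCOC(=O)c1cccnc1SNC(=O)Nc1ncccn1` gives 34000 nM in this assay and so holds the only actual number in this small set. For the measured compounds named here, these two compounds differ in more than one place, so they offer no measured step to serve as a guide.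

Compound 3 `CCOC(=O)c1cc([N+](=O)[O-])cnc1SNC(=O)Nc1ncccn1` is compound 2 with a single change: nitro in place of hydrogen on an aromatic carbon in a place two atoms from the ring nitrogen, meta to an ethoxycarbonyl group and para to a large group. Neither measured compound carries a nitro group, so the expectation in this assay is for no step beyond the usual scatter, with wide uncertainty in either direction. The expected move a 1.4-fold lower number from compound 2 to compound 3 (0.13 log units; within the scatter) is therefore a small one. Compound 3 is estimated at 25000 nM with an expected range from 8000 nM to 80000 nM on this read-out.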

Compound 3, half-maximal inhibitory concentration: 200 nM
Compound 3: the middle estimate sits 130-fold (2.10 log units) above what was measured; the measured number lies below the stated range.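

On the core of compound 2, the position two atoms from the ring nitrogen, meta to an ethoxycarbonyl group and para to a large group, proves highly sensitive in this assay: nitro in place of hydrogen on an aromatic carbon gives a 170-fold lower number from compound 2 to compound 3 (2.23 log units; beyond the scatter), which moves the read-out toward stronger inhibition. Among these compounds, the two earlier compounds differ in more than one place, so this is the first reading in the set of what a single change does, and it shows that one small substituent on this ring can shift the read-out by far more than the scatter. Compound 1 remains a limit of the assay and not a number, so the step from compound 2 to compound 3 is the only one with a measured value at both ends: the limit of > 100000 nM in this assay, at which 1 of the 3 values shown sits.

The compounds shown leave open whether this shift belongs to the nitro group itself or would also come with another group at this position, such as an amine or a nitrile. They also leave open whether the shift would survive with the ethoxycarbonyl group replaced by a carboxylic acid, and one step alone gives no cause for it.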